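A Rearranged Group on the Carbonyl Carbon

The compounds below may be only part of what the source reports. "The series", "measured", "known", "first", "only" and "open" are said of these compounds alone.

Compound 1 `O=C(NCc1ccc(S(=O)(=O)N2CCCCC2)cc1)c1cc2cnccc2s1`: "below limit of detection" (no number reported)
Compound 2 `O=C(NCc1ccc(S(=O)(=O)N2CCCCC2)cc1)c1ccn2ccnc2c1`: "not determined" (no result reported)
Compound 3 `O=C(NCc1ccc(S(=O)(=O)N2CCCCC2)cc1)c1ccc2nc[nH]c2c1`: 16%

Among the measured compounds shown here, in an ADME assay on microsomes from liver (Mus musculus) for metabolic stability, read by LC-MS, with a stated time of 30 min, tested at 1 uM (a higher number here means that more of the compound is left, a lower number that less of the compound is left), compound 3 gives 16%, the only number in this small set. The entry for compound 1 is a limit and not a number. Compound 2 has no result.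

Compound 4 `O=C(NCc1ccc(S(=O)(=O)N2CCCCC2)cc1)c1ccn2cncc2c1` has the same atoms as compound 3, joined differently, and the change sits on a carbonyl carbon: a group of 9 heavy atoms (7 carbon, 2 nitrogen; one five-membered aromatic ring with 2 hetero atoms, one six-membered aromatic ring with 1 hetero atom) in place of a group of 9 heavy atoms (7 carbon, 2 nitrogen; one five-membered aromatic ring with 2 hetero atoms, one six-membered aromatic ring of carbon only), on a carbonyl carbon. For the measured compounds named here, no measured pair shows what a change of this kind does in this assay. The expected result, a number 6 percentage points lower from compound 3 to compound 4 (within the scatter), is a change no larger than the usual scatter. For compound 4 the estimated value is 10%, with an expected range from 1% to 30%.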

Compound 4, percent of the compound remaining: 1%
The estimate for compound 4 lay 9 percentage points above the measured number; measured number inside the range.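

Among the compounds shown here, with the same atoms joined differently on the carbonyl carbon, this assay gives the first readable step in this set: a number 15 percentage points lower from compound 3 to compound 4 (beyond the scatter). The position is therefore sensitive to the arrangement of the group alone, with no change in its heavy-atom count. Nothing available explains this step.

On these data alone, it remains open whether a plain phenyl or an indol-5-yl group on the same carbonyl carbon would leave more of the compound. One step also cannot show how far this trend extends to other fused groups.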